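Amide replacement: pyrazole for fluorophenyl in a cytotoxicity series

The source may hold more compounds than are shown below. What is called first, only, known or untested is meant among the compounds shown, and "the series" means these compounds.

Of the compounds shown here, two have been tested in a toxicity assay on THP-1 cells (Homo sapiens) for inhibition; on this read-out higher numbers stand for lower toxicity in this test and lower numbers for higher toxicity in this test. Compound 1 `Cn1c(-c2ccccc2[N+](=O)[O-])cnc1NC(=O)c1ccc(F)cc1` gives 31000 nM in this assay. Compound 2 `COc1ccc(-c2cnc(NC(=O)c3ccccc3F)n2C)cc1` is reported in this assay only as a limit, > 100000 nM, and no number is available for it. Of the two values shown, compound 2 therefore sits at the limit of > 100000 nM in this assay, at which 1 of the 2 values shown sits, while compound 1 stands at a measured value some way inside the range of the assay. Going by the values given here, no pair of measured compounds differs in a single place, so no measured step is available to size the move from compound 2 to compound 3.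

Compound 3 `COc1ccc(-c2cnc(NC(=O)c3ccn[nH]3)n2C)cc1` has not yet been measured in this assay. It differs from compound 2 by 1H-pyrazol-5-yl in place of 2-fluorophenyl on a carbonyl carbon. The amide and the rest of the shared core are kept. With compound 2 at a limit in this assay, nothing within the series points to a markedly more toxic reading for compound 3. A step of no more than the usual scatter is expected, in either direction, as a number no higher from compound 2 to compound 3 (the limit leaves the size open). Compound 3 is expected at 100000 nM in this assay, within 30000 nM to 300000 nM, and a reading that is itself only a limit is likely.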

Compound 3, half-maximal cytotoxic concentration: > 100000 nM
Compound 3 gave a limit, no number (the forecaster's own chance of this, stated with the estimate: 65%); the middle value lies on the limit itself.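

Compound 2 and compound 3 both stand as limits and not as numbers in this assay, so no step can be read between them: the limit of > 100000 nM in this assay, at which 2 of the 3 values shown sit.

The compounds shown leave open whether 1H-pyrazol-5-yl in place of 2-fluorophenyl on a carbonyl carbon moves the reading in this assay at all, and if so, in which direction and by how much.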